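This account rests on a few compounds, and the source may have more. Where it says the series, first, only, none or still open, it means among the compounds named here.

Of the compounds shown here, three built on one shared core have been measured in a functional assay on HT-1080 cells (Homo sapiens) for cytotoxicity, read by MTT assay, with a stated time of 72 h; on this read-out higher numbers stand for weaker inhibition and lower numbers for stronger inhibition. Compound 1 (`COc1ccc(/C=C2\CCC/C(=C\c3cccc(OC)c3OC)C2=O)cc1OC`) gives 6400 nM, compound 2 (`COc1ccc(/C=C2\CCC/C(=C\c3cccc(Br)c3)C2=O)cc1OC`) gives 5200 nM and compound 3 (`COc1ccc(/C=C2\CCC/C(=C\c3ccc(Br)cc3)C2=O)cc1OC`) gives 4300 nM. These values all lie within the usual scatter of one another, so compound 3 stands level with the other two and no ranking can be drawn among them.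

Compound 4 (`COc1ccccc1/C=C1\CCC/C(=C\c2ccc(OC)c(OC)c2)C1=O`) has not yet been measured. It differs from compound 3 in one place, on a double-bonded chain carbon bound to a double-bonded ring carbon, where 2-methoxyphenyl stands in place of 4-bromophenyl: 2-methoxyphenyl in place of 4-bromophenyl on a double-bonded chain carbon bound to a double-bonded ring carbon.

Among the compounds with values here, the one measured step at this place is a 1.2-fold lower number from compound 2 to compound 3 (0.08 log units; within the scatter), with 4-bromophenyl in place of 3-bromophenyl, and it stays within the scatter. Within the data shown here, no measured step makes the exact swap found in compound 4. The closest evidence is compound 1, which carries methoxy groups on the group at this place and gives 6400 nM, within the scatter of compound 3. No step beyond the scatter is therefore expected in this assay. The expected change is a 1.2-fold higher number from compound 3 to compound 4 (0.07 log units; within the scatter), an estimate with no firm direction. For compound 4 the estimated value is 5000 nM, with an expected range from 2500 nM to 10000 nM.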

Compound 4, half-maximal inhibitory concentration: 8100 nM
Beside the measured number, compound 4's estimate is 1.6-fold (0.21 log units) below it, within the range that was stated.
By their numbers in this assay, from the lowest: compounds 3, 2, 1 and 4 (each within the scatter of the next).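

In this assay, within the data shown here, the first direct swap of a bromine-bearing ring for a methoxy-bearing ring at this place gives a 1.9-fold higher number from compound 3 to compound 4 (0.28 log units; within the scatter) when 2-methoxyphenyl stands in place of 4-bromophenyl on a double-bonded chain carbon bound to a double-bonded ring carbon. Set against the other bromine compound, the same place gives a 1.6-fold higher number from compound 2 to compound 4 (0.19 log units; within the scatter) and, with hydrogen in place of methoxy on an aromatic carbon, the comparison with the compound carrying more methoxy groups gives a 1.3-fold higher number from compound 1 to compound 4 (0.10 log units; within the scatter) as well. Bromophenyl and methoxyphenyl groups at this place therefore remain indistinguishable in this cell assay, and the set now holds no step beyond the scatter, even though the entering group brings a hydrogen-bond acceptor that the leaving group lacks.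

Nothing measured on these compounds bears on why the numbers stay so close. Going by these compounds, whether a group of a different kind on this ring, such as an amine or a carboxylic acid, would produce a step beyond the scatter remains open.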